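Compound 1 loses its 3-methyl-1,2-oxazol-5-yl group

A few compounds are considered here, and "the series" means these few. Any claim that something is new, unique, unknown or untested is made for them only; others in the source may bear on it.

- compound 1 `COc1cc(-c2cnn3cc(OC)c(-c4cc(C)no4)nc23)ccn1`: 62%
- compound 2 `COc1cn2ncc(-c3ccnc(OC4CC4)c3)c2nc1-c1cnn(C)c1`: 32%

In an ADME assay on microsomes from liver (Rattus norvegicus) for metabolic stability, with a stated time of 60 min, tested at 1 uM (a higher number here means that more of the compound is left, a lower number that less of the compound is left), compound 1 stands at 62% and is the higher of the two measured compounds, while compound 2 gives 32% and lies lower by a gap beyond the usual scatter.

Compound 3 `COc1cnc2c(-c3ccnc(OC)c3)cnn2c1` has not yet been measured. It differs from compound 1 in one place, with hydrogen in place of 3-methyl-1,2-oxazol-5-yl on an aromatic carbon on an aromatic carbon next to the ring nitrogen and ortho to a methoxy group.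

For the measured compounds named here, no pair of measured compounds shows this change alone, for compound 1 and compound 2 differ in more than one place. The data therefore give no firm direction, and no step beyond the scatter is expected in this assay for this change. The expected step is a number 4 percentage points lower from compound 1 to compound 3 (within the scatter) and remains only an estimate.

The estimate starts from compound 1 at 62% and stays wide, as a single change of this size has not been tested here. For compound 3 the expected value is 58% with an estimated range from 32% to 82% in this read-out.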

Compound 3, percent of the compound remaining: 10%
Compound 3: the middle estimate sits 48 percentage points above what was measured; measured number below the stated range.
By their numbers in this assay, from the lowest: compound 3; then compound 2; then compound 1.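

For the compounds shown here, the exchange of the 3-methyl-1,2-oxazol-5-yl group for hydrogen on this aromatic carbon, next to the ring nitrogen and ortho to a methoxy group, gives the first reading of this position alone in this assay: a number 52 percentage points lower from compound 1 to compound 3 (beyond the scatter). It shows that the amount of compound left after the incubation depends strongly on what this one place carries, something compound 1 and compound 2 could not show, since they differ in more than one place. The data at hand offer no measurement that explains why the number falls so far with this change.

As far as these compounds go, only the 3-methyl-1,2-oxazol-5-yl group and hydrogen can be read at this place on their own, so it stays open whether the whole five-membered ring is needed to hold the number up or whether a single methyl group, an amine or a nitrile would serve as well. From the compounds shown here alone, it is also open whether a step of this size would recur with an ethoxy group in place of the ortho methoxy group, as one change on the core of compound 1.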